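From a Ring to an Open Chain in Compound 2

The source may hold more compounds than are shown below. What is called first, only, known or untested is meant among the compounds shown, and "the series" means these compounds.

Of the compounds shown here, two have been measured so far, compound 1 (`COc1cc2ncnc(-n3cnc(-c4ccccn4)n3)c2cc1OC`) and compound 2 (`COc1cc2ncnc(-n3nc(-c4ccccn4)nc3N)c2cc1OCCCNC(=O)CN1C[C@@H](C)O[C@@H](C)C1`). In a physicochemical assay for solubility, in phosphate buffer, with a stated time of 18 h, at pH 7.4 (a lower number here means a less soluble compound, a higher number a more soluble compound), compound 1 gives 30000 nM and compound 2 gives 34000 nM, so the two numbers lie within the usual scatter of each other. These compounds differ in more than one place, so their values cannot be tied to any single structural change.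

Compound 3 (`COc1cc2ncnc(-n3nc(-c4ccccn4)nc3N)c2cc1OCCCNC(=O)OCC(C)(C)C`) differs from compound 2 in one place, with neopentyloxy in place of (2,6-dimethylmorpholin-4-yl)methyl on a carbonyl carbon. A ring leaves and an open chain enters. For the measured compounds named here, no measured pair shows this change, so the expectation is loose and rests on the structures alone. Its starting point is compound 2 at 34000 nM. In this assay, a downward move beyond the scatter is expected, with an estimated step of a 6.8-fold lower number from compound 2 to compound 3 (0.83 log units; beyond the scatter). For compound 3, the estimated value is 5000 nM, with an expected range from 800 nM to 20000 nM.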

Compound 3, solubility: 200 nM
Beside the measured number, compound 3's estimate is 25-fold (1.40 log units) above it; measured number outside the range, below it.
By their numbers in this assay, from the lowest: compound 3; then compounds 1 and 2 (each within the scatter of the next).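

In this assay, the group on the carbonyl carbon proves to have a large effect: replacing (2,6-dimethylmorpholin-4-yl)methyl with neopentyloxy gives a 170-fold lower number from compound 2 to compound 3 (2.23 log units; beyond the scatter). For the compounds shown here, this is the first step in the set that can be tied to one place in the structure, since the two compounds share everything else. That one place still holds several differences, as the ring, its nitrogen and both defined stereocentres leave, and the group goes from 9 heavy atoms to 6. No separate evidence bears on what lies behind the step.

The compounds shown therefore leave open which of these differences accounts for the drop, and whether the ring itself matters or only the nitrogen within it. An open-chain dimethylaminomethyl group on the same carbonyl carbon would keep a nitrogen without a ring, while a plain cyclohexylmethyl group would keep a ring without a nitrogen, so each would help pull these differences apart.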